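Hydroxymethyl to carboxy on two related cores

The source may report more compounds than this note shows. Statements on the series, on what has been measured and on what is new or still open speak of the compounds shown alone.

Compound 1 `O=C(CCl)Nc1ccc(Cn2nc(-c3ccc(Oc4ccccc4)cc3)cc2CO)cc1` is measured in a functional assay on Rec1 cells (Homo sapiens) for inhibition, read by luminescence and CellTiter-Glo, with a stated time of 72 h (on this read-out higher numbers stand for weaker inhibition and lower numbers for stronger inhibition), at 400 nM. For the measured compounds named here, compound 2 `O=C(CCl)Nc1ccc(Cn2nc(-c3ccc(Oc4ccccc4)cc3)cc2C(=O)O)cc1` carries the change carboxy in place of hydroxymethyl on an aromatic carbon and gives 4000 nM in this assay; the step of a 10-fold higher number from compound 1 to compound 2 (1.00 log units; beyond the scatter) is the single reference for this change within the set. Compound 3 `O=C(CCl)Nc1cccc(Cn2nc(-c3ccc(Oc4ccccc4)cc3)cc2CO)c1` is built on a core that has the same atoms as the core of compound 1 joined differently; the difference between the two cores is not broken down here. In this assay compound 3 gives 400 nM, level with compound 1 at the precision reported and within the scatter, so the two cores read alike while both carry the hydroxymethyl.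

Compound 4 `O=C(CCl)Nc1cccc(Cn2nc(-c3ccc(Oc4ccccc4)cc3)cc2C(=O)O)c1` is not yet measured. It stands to compound 3 as compound 2 stands to compound 1: the change (carboxy in place of hydroxymethyl on an aromatic carbon), at a place described in exactly the same words as before, so it is the same change rather than merely the same kind. Because the earlier instance gave a 10-fold higher number from compound 1 to compound 2 (1.00 log units; beyond the scatter) and because compound 3 sits at 400 nM where compound 1 sits, the working expectation is that compound 4 follows the same step. Going by the values given here, with only one prior instance, carry-over to the second core is an assumption, not a confirmed pattern. Compound 4 is expected in this assay at 4000 nM, with a likely range from 1500 nM to 10000 nM. The estimated step of a 10-fold higher number from compound 3 to compound 4 (1.00 log units; beyond the scatter) is expected to match the earlier one in direction and size.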

Compound 4, half-maximal inhibitory concentration: 7100 nM
Compound 4: the middle estimate sits 1.8-fold (0.25 log units) below what was measured; low and high end bracket the measured number.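

In this assay, carboxy in place of hydroxymethyl on an aromatic carbon moves the number the same way on both cores, and the two steps do not differ beyond the scatter: the same change on two cores in this assay, a 10-fold higher number (1.00 log units; beyond the scatter) from compound 1 to compound 2 and an 18-fold higher number (1.25 log units; beyond the scatter) from compound 3 to compound 4, 1.8-fold (0.25 log units) apart, within the scatter of two such steps

On the second core the change gives an 18-fold higher number from compound 3 to compound 4 (1.25 log units; beyond the scatter), while the swap of 4-(((chloromethyl)carbonyl)amino)phenyl for 3-(((chloromethyl)carbonyl)amino)phenyl gives a 1.8-fold higher number from compound 2 to compound 4 (0.25 log units; within the scatter), so the two cores read alike with carboxy as they do with hydroxymethyl. This is a match across two matched pairs on two closely related cores only: it supports carrying the change between these cores in this one cell assay, but it does not show that the change would carry to any other core, and it says nothing about why the number rises.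

The compounds shown leave open how other groups at the same ring carbon would read on either core, such as a primary amide, a methyl ester, an aminomethyl group or a longer chain ending in hydroxyl. They also leave open whether the step holds when the chloromethyl carbonyl group is replaced, for instance by an acryloyl group or a plain acetyl group.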